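Opening a Carbamoyl Group: From Compound 3 to Compound 4

The source may report more compounds than this note shows. Statements on the series, on what has been measured and on what is new or still open speak of the compounds shown alone.

Three compounds share a core in which a piperazine-like ring carries a carbonyl group on one side and a thiocarbonyl sulfur linker to a triazole on the other. Compound 1 `CCN(C)C(=O)N1CCN(C(=S)SCc2cn(Cc3ccc(F)cc3)nn2)CC1` carries an ethyl(methyl)carbamoyl group and a fluoro on its outer aromatic ring; in a functional assay on MGC-803 cells (Homo sapiens) for cytotoxicity, read by MTT assay, with a stated time of 72 h (on this read-out higher numbers stand for weaker inhibition and lower numbers for stronger inhibition), compound 1 gives 1550 nM. Compound 2 `CCN(C)C(=O)N1CCN(C(=S)SCc2cn(Cc3ccc(C)cc3)nn2)CC1` differs only by a methyl in place of that fluoro, and in this assay compound 2 gives 8270 nM. That single swap gave a 5.3-fold higher number from compound 1 to compound 2 (0.73 log units; beyond the scatter). Compound 3 `COc1ccc(Cn2cc(CSC(=S)N3CCN(C(N)=O)CC3)nn2)cc1` has a plain carbamoyl group and a methoxy on the aromatic ring. For compound 3 this assay reports only > 128000 nM, which is a limit of the measurement and not a number, as set out by the limit of > 128000 nM in this assay, at which 1 of the 3 values shown sits.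

Compound 4 `CCN(C)C(=O)N1CCN(C(=S)SCc2cn(Cc3ccc(OC)cc3)nn2)CC1` takes the step (ethyl(methyl)amino in place of amino on a carbonyl carbon). Among the compounds with values here, no measured step bears directly on this change; compounds 1 and 2 simply show that the ethyl(methyl)carbamoyl core can reach the values above. Compound 4 is therefore expected to land near those, at an estimated 6000 nM, within 1500 nM to 40000 nM. That would mean an expected step of an at least 21-fold lower number from compound 3 to compound 4 (1.32 log units; beyond the scatter).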

Compound 4, half-maximal inhibitory concentration: 87900 nM
Compound 4: the middle estimate sits 15-fold (1.17 log units) below what was measured, outside the stated range (above it).
By their numbers in this assay, from the lowest: compound 1; then compound 2; then compound 4. At a limit, above all of these: compound 3.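

In this assay, the change from carbamoyl to ethyl(methyl)carbamoyl gives an at least 1.4-fold lower number from compound 3 to compound 4 (0.16 log units; that floor lies within the scatter), which is only a floor and not the true size of the step, so this change is not shown to matter on its own. Compound 3 is known only through a limit of the measurement: the limit of > 128000 nM in this assay, at which 1 of the 4 values shown sits.

The clearer news concerns the group on the aromatic carbon, where the ethyl(methyl)carbamoyl group stays fixed and methoxy gives an 11-fold higher number from compound 2 to compound 4 (1.03 log units; beyond the scatter) and a 57-fold higher number from compound 1 to compound 4 (1.75 log units; beyond the scatter), both large steps that show this site moves the number much further than the earlier swap of fluoro for methyl did.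

As far as these compounds go, whether a chlorine, a hydroxyl group or a longer chain on that aromatic carbon would give numbers closer to those of compound 1 or of compound 4 remains open. Also open, from the compounds shown here alone, is how large the step from carbamoyl to ethyl(methyl)carbamoyl is when both partners in the pair give a real number instead of a limit.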